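Carboxylate chain variations on a bicyclic amide-acid scaffold

The source may hold more compounds than are shown below. What is called first, only, known or untested is meant among the compounds shown, and "the series" means these compounds.

Three compounds sharing one core were examined for growth inhibition of breast cancer cells. Compound 1 `CCCCNC(=O)C1C(C(=O)O)[C@@H]2CC[C@H]1O2` carries a plain butyl chain on the amide nitrogen, compound 2 `O=C(O)CCCNC(=O)C1C(C(=O)O)[C@@H]2CC[C@H]1O2` a shorter chain ending in a carboxy group, and compound 3 `O=C(O)CCCCCCCNC(=O)C1C(C(=O)O)[C@@H]2CC[C@H]1O2` a longer chain ending in a carboxy group. In an ADME assay on MCF7 cells (Homo sapiens) for cytotoxicity, read by MTT assay, with a stated time of 72 h (a higher number here means a weaker inhibitor of growth, a lower number a stronger inhibitor of growth), compound 1 gives 10000 nM, compound 2 gives 10000 nM and compound 3 gives 10000 nM. The step of no change at the digits printed from compound 2 to compound 1 (within the scatter) is flat, as is no change at the digits printed from compound 1 to compound 3 (within the scatter), and no change at the digits printed from compound 2 to compound 3 (within the scatter) shows the same. Within this small set no compound can be set apart from another in this assay.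

Compound 4 `CCCCCCCCNC(=O)C1C(C(=O)O)[C@@H]2CC[C@H]1O2` has not yet been measured. It differs from compound 3 by methyl in place of carboxy on a saturated chain carbon, seven bonds along the chain from an amide-type nitrogen. The same kind of change is seen in measured compounds as methyl in place of carboxy on a saturated chain carbon, three bonds along the chain from an amide-type nitrogen, the one sitting three bonds along the chain from an amide-type nitrogen and the other seven bonds along the chain from an amide-type nitrogen. The cores of compound 3 and compound 2 differ by 4-carboxybutyl in place of carboxy on a saturated chain carbon, three bonds along the chain from an amide-type nitrogen.

The measured step for this kind of change, no change at the digits printed from compound 2 to compound 1 (within the scatter), was flat, so the expected step of no change at the digits printed from compound 3 to compound 4 (within the scatter) in this assay is also flat, resting on compound 2 at 10000 nM and compound 1 at 10000 nM. Compound 4 is therefore estimated at 10000 nM, with an expected range from 5000 nM to 20000 nM.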

Compound 4, concentration for 50% growth inhibition: 10000 nM
Compound 4: middle estimate and measured number agree at the digits printed; the range from low to high includes it.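

In this assay, methyl in place of carboxy on a saturated chain carbon, seven bonds along the chain from an amide-type nitrogen, gives no change at the digits printed from compound 3 to compound 4 (within the scatter), and the two other steps that end at the new compound read the same, with no change at the digits printed from compound 2 to compound 4 (within the scatter) and no change at the digits printed from compound 1 to compound 4 (within the scatter). Set beside the earlier step for the same kind of change, made three bonds along the chain from an amide-type nitrogen, the change carries from one core to the other with no difference that can be told apart: the same change on two cores in this assay, no change at the digits printed (within the scatter) from compound 2 to compound 1 and no change at the digits printed (within the scatter) from compound 3 to compound 4, 1.0-fold (0.00 log units) apart, within the scatter of two such steps This shows only that the change is flat on both cores in this assay; with all four compounds level, it does not show that the two steps would still match on a core where the change moved the number, nor does it give any measure of how well a step of real size would carry over.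

The compounds shown leave open whether any change to this chain can move the result in this assay. Going by these compounds, an amine or a hydroxy group at the chain end, a longer chain, or an ester in place of the carboxylic acid on the shared core remain untested here.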